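Two aryl-thiazole acids and a trifluoromethylsulfanyl analogue

The source may report more compounds than this note shows. Statements on the series, on what has been measured and on what is new or still open speak of the compounds shown alone.

Compound 1 `O=C(O)CCNC(=O)c1ccc(CC(c2ccc(Cl)cc2)c2nc(-c3ccc(C(F)(F)F)cc3)cs2)cc1`: 96 nM
Compound 2 `Cc1cc(N(Cc2ccc(C(=O)NCCC(=O)O)cc2)c2nc(-c3ccc(C(F)(F)F)cc3)cs2)ccc1C(C)C`: 119 nM

Both compounds were tested in an in vitro assay on BHK cells for displacement of a labelled ligand from Glucagon receptor (Homo sapiens), read by scintillation proximity assay; on this read-out higher numbers stand for weaker inhibition and lower numbers for stronger inhibition. In that test compound 1 gives 96 nM, and compound 2 gives 119 nM. Compound 2 therefore holds the highest of the two numbers, but its nearest neighbour is compound 1, and the gap between the two values lies within the scatter of the method, so no order between them can be stated.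

Compound 3 `O=C(O)CCNC(=O)c1ccc(CN(c2ccc(SC(F)(F)F)cc2)c2nc(-c3ccc(C(F)(F)F)cc3)cs2)cc1` has not yet been measured. It differs from compound 2 in one place: 4-((trifluoromethyl)sulfanyl)phenyl in place of 4-isopropyl-3-methylphenyl on a nitrogen on an aromatic ring. The shared core of compound 2 is otherwise kept, as are the acid-bearing side chain and the trifluoromethylphenyl on the other end of the molecule.

Going by the values given here, since no pair of measured compounds differs in exactly this way, there is no measured step to lean on. The two measured values sit close together, and the change keeps a single six-membered aromatic ring of carbon only in the same place, so the expected step in this assay is small, with no direction beyond the scatter: the estimated step is a 1.1-fold lower number from compound 2 to compound 3 (0.03 log units; within the scatter). On that basis compound 3 is expected to give about 110 nM, estimated to fall between 40 nM and 330 nM.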

Compound 3, half-maximal inhibitory concentration: 34 nM
Beside the measured number, compound 3's estimate is 3.2-fold (0.51 log units) above it; measured number below the stated range.
By their numbers in this assay, from the lowest: compound 3; then compounds 1 and 2 (each within the scatter of the next).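

Among the compounds shown, this is the first change that can be read at this place, on a nitrogen on an aromatic ring, since compound 1 and compound 2 differ in more than one place. In this assay, 4-((trifluoromethyl)sulfanyl)phenyl in place of 4-isopropyl-3-methylphenyl gives a 3.5-fold lower number from compound 2 to compound 3 (0.54 log units; beyond the scatter), so the choice of group here can move the number even though the step is modest. Both groups hold one six-membered aromatic ring of carbon only, no hydrogen-bond donor and no net charge, so the step comes with those counts unchanged, while sulfur and fluorine enter and the count of hydrogen-bond acceptors differs, and nothing measured here ties it to any property of either group.

The compounds shown leave open which part of the entering group goes with the step, a question that 4-(methylsulfanyl)phenyl or 4-(trifluoromethoxy)phenyl at the same place could help to separate. They also leave open whether the same exchange would give a similar step on the core of compound 1.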